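The source may report more compounds than this note shows. Statements on the series, on what has been measured and on what is new or still open speak of the compounds shown alone.

Measured compounds in an assay on cells for inhibition of diacylglycerol lipase-alpha (Mus musculus), with stated times of 20 min and 30 min; a higher number here means a weaker inhibitor, a lower number a stronger inhibitor:
- compound 1, `O=C(N1CCCC[C@@H]1Cc1ccccc1)n1ncc(C(O)(c2ccc(F)cc2)c2ccc(F)cc2)n1`: 10.4 nM
- compound 2, `Cc1ccc(-c2cnc3nc(C(=O)CCCCCc4ccccc4)oc3c2)cc1`: 0.23 nM
- compound 3, `O=C(N1CCCC[C@@H]1Cc1ccccc1)n1cc(C(O)(c2ccc(F)cc2)c2ccc(F)cc2)nn1`: 339 nM

Compound 1 sits second highest among these three numbers. Its nearest neighbour is compound 3, whose number is higher by a gap that lies beyond the usual scatter of repeated measurements, so compound 3 is the weaker inhibitor of the two. Compound 2 lies furthest away, with a number far lower than that of compound 1, again well beyond the scatter, and it is the strongest inhibitor in this small set.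

The piece now follows a single change made to compound 1, giving compound 4, `C#CCO[C@@H]1CC[C@H](Cc2ccccc2)N(C(=O)n2ncc(C(O)(c3ccc(F)cc3)c3ccc(F)cc3)n2)C1`, which has not yet been measured in this assay. The change is propargyloxy in place of hydrogen on a saturated ring carbon. The core of compound 1 is kept whole; only a hydrogen on the saturated ring is exchanged for a small chain carrying one hydrogen-bond acceptor and a triple bond.

Among the compounds with values here, no pair of measured compounds differs by this kind of change, so there is no measured step to lean on. A small group added at this place is expected to shift the number little, perhaps slightly downward, so a step of a 1.3-fold lower number from compound 1 to compound 4 (0.11 log units; within the scatter) of modest size is estimated. Compound 4 is therefore expected to give 8 nM in this assay, within a range from 2 nM to 40 nM.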

Compound 4, inhibition constant: 0.27 nM
Beside the measured number, compound 4's estimate is 30-fold (1.47 log units) above it; the whole stated range lies above it.
By their numbers in this assay, from the lowest: compounds 2 and 4 (each within the scatter of the next); then compound 1; then compound 3.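

In this assay, the saturated ring carbon two ring bonds from the ring nitrogen proves to be a sensitive place on compound 1: propargyloxy in place of hydrogen there gives a 39-fold lower number from compound 1 to compound 4 (1.59 log units; beyond the scatter), a large step towards stronger inhibition. Within the data shown here, the earlier compounds included no pair differing at this carbon, so this is the first sign that the number responds to what is attached there, and that a chain of 4 heavy atoms ending in a triple bond is tolerated on the core of compound 1. Nothing available explains why the number falls so far.

A single change cannot separate the contribution of the oxygen from that of the triple bond; a methoxy group, or a propoxy chain with no triple bond, at the same carbon would begin to pull the two apart. The compounds shown also leave open how an amine, a hydroxyl group or a longer chain would read at this carbon, and whether the propargyloxy group would give a similar number with the opposite arrangement in space.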